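Compound 3 to 4-bromophenyl: expected step for compound 4

The source may report more compounds than this note shows. Statements on the series, on what has been measured and on what is new or still open speak of the compounds shown alone.

Measured in a functional assay on MCF7 cells (Homo sapiens) for cytotoxicity, read by MTT assay, with a stated time of 72 h; on this read-out higher numbers stand for weaker inhibition and lower numbers for stronger inhibition:
- compound 1 `O=C(/C=C/c1cccc(Cl)c1Cl)Nc1cc2c(Nc3ccc(F)c(Cl)c3)ncnc2cc1O[C@H]1CCOC1`: 30100 nM
- compound 2 `COc1cc(/C=C/C(=O)Nc2cc3c(Nc4ccc(F)c(Cl)c4)ncnc3cc2O[C@H]2CCOC2)cc(OC)c1OC`: 28400 nM
- compound 3 `COc1ccc(/C=C/C(=O)Nc2cc3c(Nc4ccc(F)c(Cl)c4)ncnc3cc2O[C@H]2CCOC2)c(OC)c1OC`: 4650 nM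

Compound 3 has the lowest number of the three. Unmeasured compound 4 `O=C(/C=C/c1ccc(Br)cc1)Nc1cc2c(Nc3ccc(F)c(Cl)c3)ncnc2cc1O[C@H]1CCOC1` carries 4-bromophenyl in place of 2,3,4-trimethoxyphenyl on a double-bonded chain carbon bound to a double-bonded chain carbon. Going by the values given here, three measured steps bear on this. a 1.1-fold lower number from compound 1 to compound 2 (0.03 log units; within the scatter) shows that the aryl groups of those two compounds do not separate. a 6.5-fold lower number from compound 1 to compound 3 (0.81 log units; beyond the scatter) and a 6.1-fold lower number from compound 2 to compound 3 (0.79 log units; beyond the scatter) both arrive at the 2,3,4-trimethoxyphenyl group. Leaving that group is therefore expected to raise the number in this assay by a similar size, though no 4-bromophenyl compound has been measured. The expected step is a 4.3-fold higher number from compound 3 to compound 4 (0.63 log units; beyond the scatter). For compound 4 the estimate is 20000 nM, with an expected range of 7000 nM to 45000 nM.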

Compound 4, half-maximal inhibitory concentration: 32400 nM
For compound 4 the middle estimate is 1.6-fold (0.21 log units) below the measured one; the range from low to high includes it.
By their numbers in this assay, from the lowest: compound 3; then compounds 2, 1 and 4 (each within the scatter of the next).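

In this assay the change to 4-bromophenyl gives a 7.0-fold higher number from compound 3 to compound 4 (0.84 log units; beyond the scatter) and so confirms that 2,3,4-trimethoxyphenyl stands apart at this position. Against the other two groups, the result is a 1.1-fold higher number from compound 2 to compound 4 (0.06 log units; within the scatter) and a 1.1-fold higher number from compound 1 to compound 4 (0.03 log units; within the scatter) and does not separate 4-bromophenyl from 3,4,5-trimethoxyphenyl or 2,3-dichlorophenyl, so among these four compounds only the 2,3,4-trimethoxyphenyl compound differs. No evidence on the origin of this difference is available.

Open, as far as these compounds go, is how a phenyl group carrying an amine or a carboxylic acid would compare with 2,3,4-trimethoxyphenyl at this place.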